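Moving the attachment point on the indane of compound 3

A few compounds are considered here, and "the series" means these few. Any claim that something is new, unique, unknown or untested is made for them only; others in the source may bear on it.

Compound 3 `c1ccc2c(c1)CCC2CCCN1CCN(c2cccc3c2OCCO3)CC1` gives the lowest number of the three in an assay for activation of Adrenergic receptor alpha-1 (Rattus norvegicus) (a lower number here means that less compound is needed, a higher number that more compound is needed for the effect), namely 0.23 mg/kg. Its nearest neighbour is compound 1 `c1ccc2c(c1)CC2CCCN1CCN(c2cccc3c2OCCO3)CC1`, which gives 0.45 mg/kg; the step between them, a 2.0-fold lower number from compound 1 to compound 3 (0.29 log units; within the scatter), is within the scatter. Compound 2 `c1ccc2c(c1)CC2CCCCN1CCN(c2cccc3c2OCCO3)CC1` gives 7.15 mg/kg, and the step of a 31-fold lower number from compound 2 to compound 3 (1.49 log units; beyond the scatter) is large and beyond the scatter, as is a 16-fold higher number from compound 1 to compound 2 (1.20 log units; beyond the scatter).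

Compound 4 `c1ccc2c(c1)CC(CCCN1CCN(c3cccc4c3OCCO4)CC1)C2` keeps every atom of compound 3 but joins them differently: 2,3-dihydro-1H-inden-2-yl in place of 2,3-dihydro-1H-inden-1-yl on a saturated chain carbon, three bonds along the chain from an amine nitrogen in a ring. For the measured compounds named here, no measured step changes the attachment point on a ring in this way. The step from compound 1 to compound 3 shows that altering the non-aromatic ring at this place left the number within the scatter, whereas the steps from compound 1 to compound 2 and from compound 2 to compound 3 show that a longer chain between the rings and the ring nitrogen raised the number strongly. Since compound 4 keeps the chain length of compound 3, only a small step is expected, a 2.2-fold higher number from compound 3 to compound 4 (0.34 log units; beyond the scatter), with a modest rise as the more likely direction. Compound 4 is therefore estimated to give 0.5 mg/kg in this assay, within a range from 0.15 mg/kg to 2 mg/kg.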

Compound 4, dose for half-maximal effect: 1.73 mg/kg
Estimate against measurement, compound 4: 3.5-fold (0.54 log units) below, and the stated range covers the measured number.
By their numbers in this assay, from the lowest: compounds 3 and 1 (each within the scatter of the next); then compound 4; then compound 2.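

In this assay, for the compounds shown here, 2,3-dihydro-1H-inden-2-yl in place of 2,3-dihydro-1H-inden-1-yl gives a 7.5-fold higher number from compound 3 to compound 4 (0.88 log units; beyond the scatter), so changing only how the same atoms are joined at this place moves the number beyond the scatter, something no earlier step could show. The earlier step from compound 1 to compound 3 had left the number within the scatter, but a 3.8-fold higher number from compound 1 to compound 4 (0.58 log units; beyond the scatter) shows that a five-membered non-aromatic ring does not in itself keep the number level with compound 1: the outcome also depends on where that ring is joined to the chain. Even so, the change to the inden-2-yl group does not reach the level of the compound with the longer chain, as a 4.1-fold lower number from compound 2 to compound 4 (0.62 log units; beyond the scatter) shows.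

The compounds shown offer no information on the reason for this shift. From the compounds shown here alone, it remains open whether a longer chain on the 2,3-dihydro-1H-inden-2-yl group would raise the number as strongly as it did in compound 2, and how a methoxy group or a fluorine on the aromatic ring of either indane would affect the gap between the two attachment points.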